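This account rests on a few compounds, and the source may have more. Where it says the series, first, only, none or still open, it means among the compounds named here.

Measured compounds:
Compound 1 `Cc1cc(N2CC[C@@H](C)[C@@H](N(C)c3ncnc4[nH]ccc34)C2)n2ncnc2n1`: 11300 nM
Compound 2 `Cc1cc(N2CC[C@@H](C)[C@@H](N(C)c3ncnc4[nH]ccc34)C2)n2nc(SCc3ccc(C(F)(F)F)cc3)nc2n1`: 9540 nM
Compound 3 `Cc1cc(N2CC[C@@H](C)[C@@H](N(C)c3ncnc4[nH]ccc34)C2)n2nc(SCc3cc(Cl)ccc3Cl)nc2n1`: 19200 nM

These three share one core and were tested in a functional assay on HGC-27 cells (Homo sapiens) for inhibition, read by MTT assay, with a stated time of 72 h; a lower number here means a stronger inhibitor, a higher number a weaker inhibitor. Compound 1 gives 11300 nM, the second highest of the three numbers, yet every gap here is small: from compound 1 the nearest is a 1.2-fold lower number from compound 1 to compound 2 (0.07 log units; within the scatter) and the furthest is a 1.7-fold higher number from compound 1 to compound 3 (0.23 log units; within the scatter), both within the scatter, as is a 2.0-fold higher number from compound 2 to compound 3 (0.30 log units; within the scatter).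

Compound 4 `Cc1cc(N2CC[C@@H](C)[C@@H](N(C)c3ncnc4[nH]ccc34)C2)n2nc(SCc3ccccc3Br)nc2n1` is not yet measured. It differs from compound 1 by (2-bromobenzyl)sulfanyl in place of hydrogen on an aromatic carbon. Among the compounds with values here, the steps that bear on it are the two in which a benzylsulfanyl group replaces the same hydrogen, a 1.2-fold lower number from compound 1 to compound 2 (0.07 log units; within the scatter) and a 1.7-fold higher number from compound 1 to compound 3 (0.23 log units; within the scatter), and the swap between the two aromatic rings on that group, a 2.0-fold higher number from compound 2 to compound 3 (0.30 log units; within the scatter). None of these moved the number beyond the scatter, so no step beyond the scatter is expected in this assay for compound 4 either. Compound 4 is therefore expected to give about 13000 nM, within a range of 6000 nM to 28000 nM. The step this expectation implies is a 1.2-fold higher number from compound 1 to compound 4 (0.06 log units; within the scatter).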

Compound 4, half-maximal inhibitory concentration: 21300 nM
For compound 4 the middle estimate is 1.6-fold (0.21 log units) below the measured one; the range from low to high includes it.
By their numbers in this assay, from the lowest: compounds 2, 1, 3 and 4 (each within the scatter of the next, the first and the last beyond it).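

In this assay, the step to the (2-bromobenzyl)sulfanyl group is a 1.9-fold higher number from compound 1 to compound 4 (0.28 log units; within the scatter) and so, like the two earlier benzylsulfanyl groups on this aromatic carbon, it stays within the scatter of the hydrogen in compound 1. Within the data shown here, what is new is the first separation beyond the scatter between two compounds that differ only in the aromatic ring of this group: a 2.2-fold higher number from compound 2 to compound 4 (0.35 log units; beyond the scatter) for 2-bromophenyl in place of 4-(trifluoromethyl)phenyl, a modest step, while the change from 2,5-dichlorophenyl to 2-bromophenyl is a 1.1-fold higher number from compound 3 to compound 4 (0.05 log units; within the scatter) and does not separate those two compounds. No measurement is available that would explain this small difference between the rings.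

The compounds shown all carry either hydrogen or a benzylsulfanyl group at this position. On these data alone, how an amine, a carboxylic acid or a longer alkyl chain on this carbon would compare remains open.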